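Swapping a Large Sulfur Substituent for a Small Amine

This account rests on a few compounds, and the source may have more. Where it says the series, first, only, none or still open, it means among the compounds named here.

Measured so far:
compound 1 `Cc1c(C(=O)N=C(N)N)cc(S(C)(=O)=O)c(Cl)c1[N+](=O)[O-]`: 44 nM
compound 2 `Cc1c(C(=O)N=C(N)N)cc(S(C)(=O)=O)c(C)c1C`: 55 nM
compound 3 `Cc1cc(Sc2ccccc2Cl)c(S(C)(=O)=O)cc1C(=O)N=C(N)N`: 14 nM

In a functional assay for inhibition of sodium/hydrogen exchanger (Oryctolagus cuniculus) (a lower number here means a stronger inhibitor, a higher number a weaker inhibitor), compound 3 gives the lowest of the three numbers; compound 1 stands a step away that lies beyond the usual scatter, and compound 2 lies further still. Compound 4 `Cc1cc(N)c(S(C)(=O)=O)cc1C(=O)N=C(N)N` differs from compound 3 in one place: amino in place of (2-chlorophenyl)sulfanyl on an aromatic carbon. Within the data shown here, no measured pair shows this exact change, so the expectation rests on the spread of the three numbers: compounds 1 and 2, which carry no such large group, both give higher numbers than compound 3. The estimated 4.3-fold higher number from compound 3 to compound 4 (0.63 log units; beyond the scatter) is therefore expected to run toward a weaker inhibitor, beyond the scatter. Compound 4 is estimated at 60 nM, within 20 nM to 180 nM.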

Compound 4, half-maximal inhibitory concentration: 16 nM
Beside the measured number, compound 4's estimate is 3.8-fold (0.57 log units) above it; the measured number lies below the stated range.
By their numbers in this assay, from the lowest: compounds 3 and 4 (each within the scatter of the next); then compounds 1 and 2 (each within the scatter of the next).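

In this assay, amino in place of (2-chlorophenyl)sulfanyl gives a 1.1-fold higher number from compound 3 to compound 4 (0.06 log units; within the scatter). At this position, ortho to a methylsulfonyl group, the large ring-bearing substituent can therefore be removed with no step beyond the scatter, something compounds 1 and 2 could not show, as each differs from compound 3 in more than one place. Nothing available explains why the two groups read alike. Still open, from the compounds shown here alone, is whether this position accepts almost any group, or whether a plain hydrogen, a dimethylamino group or a carboxylic acid there would shift the number.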